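The compounds below may be only part of what the source reports. "The series", "measured", "known", "first", "only" and "open" are said of these compounds alone.

Compound 1, `CCCNCc1ccc(OCCCCCC(=O)OCC)cc1`, in an ADME assay on HEK293 cells (Homo sapiens) for cytotoxicity, read by CellTiter-Glo and resazurin assay, with a stated time of 72 h (a lower number here means that less compound is needed, a higher number that more compound is needed for the effect), gives > 26000 nM, a limit of the assay.
Compound 2, `CCOC(=O)CCCCCOc1ccc(C(O)O)cc1`, in this assay gives > 27100 nM, also a limit of the assay.

Compound 2 therefore stands at a limit, as does compound 1, and the step that the two limits leave unreadable from compound 1 to compound 2 cannot be read between the limit of > 26000 nM in this assay, at which 1 of the 2 values shown sits, and (the limit of > 27100 nM in this assay, at which 1 of the 2 values shown sits). Compound 3, `CCOC(=O)CCCCCOc1ccc(CO)cc1`, differs from compound 2 by hydrogen in place of hydroxy on a saturated chain carbon bound to an aromatic carbon and an oxygen on a saturated carbon. Going by the values given here, no measured step bears readably on this change, so compound 3 is expected to show no step beyond the scatter, a step that the limit leaves unreadable from compound 2 to compound 3, and most likely only a limit again. Compound 3 is estimated at 30000 nM, between 15000 nM and 100000 nM.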

Compound 3, half-maximal effective concentration: > 27100 nM
Compound 3: only a limit was reported; the forecaster's own chance of this, stated with the estimate: 85%; the middle value does not contradict the limit.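

Compound 1, compound 2 and compound 3 all stand at limits in this assay, so no step can be read among them. From the compounds shown here alone, the concentration at which any of them reaches the half-maximal effect remains open.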